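This account rests on a few compounds, and the source may have more. Where it says the series, first, only, none or still open, it means among the compounds named here.

Measured compounds:

Compound 1 `COC(=O)[C@@]1(C)CCC=C2[C@@H]1CC[C@@H](C)[C@]2(C)Cc1c[nH]c2c(Br)cccc12`: 32000 nM
Compound 2 `COC(=O)[C@@]1(C)CCC=C2[C@@H]1CC[C@@H](C)[C@]2(C)Cc1c[nH]c2c(Cl)cccc12`: 31000 nM
Compound 3 `COC(=O)[C@@]1(C)CCC=C2[C@@H]1CC[C@@H](C)[C@]2(C)Cc1c(C)[nH]c2ccc(Br)cc12`: 15000 nM

In a functional assay on WiDr cells (Homo sapiens) for inhibition, read by sulforhodamine B assay, with a stated time of 48 h (on this read-out higher numbers stand for weaker inhibition of growth and lower numbers for stronger inhibition of growth), compound 1 gives 32000 nM and compound 2 gives 31000 nM. The change between them is chloro in place of bromo on an aromatic carbon, and it made the step of a 1.0-fold lower number from compound 1 to compound 2 (0.01 log units; within the scatter). Compound 3 gives 15000 nM in this assay, the lowest of the three numbers, beyond the scatter from both compound 1 and compound 2. The difference between the core of compound 3 and the core of compound 1 is not broken down here.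

Compound 4 `COC(=O)[C@@]1(C)CCC=C2[C@@H]1CC[C@@H](C)[C@]2(C)Cc1c(C)[nH]c2ccc(Cl)cc12` is the not yet measured partner of compound 3. It differs from compound 3 by chloro in place of bromo on an aromatic carbon. This is the same kind of change as that from compound 1 to compound 2, but not the same: there the place was ortho to a fused ring and meta to a fused ring, here it is meta to a fused ring and para to a fused ring.

For the measured compounds named here, for compound 4 a step of about no change at the digits printed from compound 3 to compound 4 (within the scatter) is expected in this assay, because the matched pair gave a 1.0-fold lower number from compound 1 to compound 2 (0.01 log units; within the scatter) and the halogen swap is the only change. Compound 4 is estimated at 15000 nM, with a range from 7000 nM to 32000 nM.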

Compound 4, concentration for 50% growth inhibition: 18000 nM
Beside the measured number, compound 4's estimate is 1.2-fold (0.08 log units) below it, within the range that was stated.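

In this assay, the swap of chloro in place of bromo gives a 1.2-fold higher number from compound 3 to compound 4 (0.08 log units; within the scatter), so the change has now been read on two cores, and the two steps agree: the same change on two cores in this assay, a 1.0-fold lower number (0.01 log units; within the scatter) from compound 1 to compound 2 and a 1.2-fold higher number (0.08 log units; within the scatter) from compound 3 to compound 4, 1.2-fold (0.09 log units) apart, within the scatter of two such steps

Within these two pairs, the swap can be carried from one core to the other without a step beyond the scatter, both where the halogen is ortho to a fused ring and meta to a fused ring and where it is meta to a fused ring and para to a fused ring. This does not show that the result holds on other cores or at other places, and the two pairs differ in both core and halogen place, so these two factors cannot be separated here.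

The compounds shown leave open whether an amine or a methoxy group in place of the halogen would give a step beyond the scatter. They also leave open what a carboxylic acid in place of the methyl ester would do to growth inhibition on either core.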